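The source may report more compounds than this note shows. Statements on the series, on what has been measured and on what is new or still open speak of the compounds shown alone.

Compound 1, with structure `CCN(CCC(Oc1ccc(C(F)(F)F)cc1)c1ccccc1)CC(=O)O`, gives the highest of the three values recorded in an assay on CHO cells for inhibition of sodium- and chloride-dependent glycine transporter 1 (Homo sapiens) (a lower number here means a stronger inhibitor, a higher number a weaker inhibitor), at 5010 nM. Compound 2, `CN(CCC(Oc1cccc(C(F)(F)F)c1)c1ccccc1)CC(=O)O`, lies nearest to it with 2510 nM, a difference within the scatter, while compound 3, `CN(CC[C@H](Oc1ccc(-c2ccccc2)cc1)c1ccccc1)CC(=O)O`, lies furthest away with 977 nM, a gap beyond the scatter. Compound 4, `CN(CCCC(=O)O)CCC(Oc1ccc(C(F)(F)F)cc1)c1ccccc1`, has not yet been measured; it differs from compound 1 by (3-carboxypropyl)(methyl)amino in place of (carboxymethyl)(ethyl)amino on a saturated chain carbon, three bonds along the chain from an aromatic carbon and an oxygen on an aromatic ring. Going by the values given here, no measured pair shows this change, so its effect can only be guessed. A modest weakening, or none beyond the scatter, seems the most likely outcome, and the step of a 1.6-fold higher number from compound 1 to compound 4 (0.20 log units; within the scatter) is therefore expected to be small. Compound 4 is estimated at 8000 nM, with a plausible range from 3000 nM to 25000 nM.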

Compound 4, half-maximal inhibitory concentration: 100000 nM
Estimate against measurement, compound 4: 13-fold (1.10 log units) below; measured number above the stated range.
By their numbers in this assay, from the lowest: compound 3; then compounds 2 and 1 (each within the scatter of the next); then compound 4.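

In this assay, going by these compounds alone, (3-carboxypropyl)(methyl)amino in place of (carboxymethyl)(ethyl)amino on this saturated chain carbon gives a 20-fold higher number from compound 1 to compound 4 (1.30 log units; beyond the scatter), so this position is far from indifferent to the change, which no earlier pair could show. Nothing available here bears on the reason for this step.

The change alters both the chain carrying the carboxylic acid and the other substituent on the nitrogen, so the compounds shown do not separate the two. On these data alone, it remains open how a (2-carboxyethyl)(methyl)amino or (3-carboxypropyl)(ethyl)amino group would read on the core of compound 1.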